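The source may hold more compounds than are shown below. What is called first, only, known or untested is meant among the compounds shown, and "the series" means these compounds.

Working notes on the series. The shared core of compound 1 `COc1ccc(CN2C(=O)C(=O)c3cc(/C=C/C(=O)OCCO)ccc32)cc1` carries a benzyl-type group on the ring nitrogen and an acrylate side chain; in a functional assay on HT-29 cells (Homo sapiens) for cytotoxicity, read by MTT assay, with a stated time of 48 h (on this read-out lower numbers stand for stronger inhibition and higher numbers for weaker inhibition), compound 1 gives 550 nM. Compound 2 `CCCCc1ccc2c(c1)C(=O)C(=O)N2` lacks both and in this assay reaches only the limit > 10000 nM, which is not a number. Compound 3 `COC(=O)/C=C/c1ccc2c(c1)C(=O)C(=O)N2Cc1cc(C)cc(C)c1` gives 70 nM in this assay, the lowest of the two numbers shown, with compound 1 clearly higher, beyond the scatter.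

Compound 4 `COC(=O)/C=C/c1ccc2c(c1)C(=O)C(=O)N2Cc1ccccc1` is not yet measured. It differs from compound 3 in one place: phenyl in place of 3,5-dimethylphenyl on a saturated chain carbon bound to an amide-type nitrogen in a ring. Within the data shown here, no measured pair isolates this change. The step from compound 3 to compound 4 in this assay is expected to be a modest rise in the number, a 2.6-fold higher number from compound 3 to compound 4 (0.41 log units; beyond the scatter), close to the edge of the scatter. Compound 4 is therefore estimated at 180 nM in this assay, within 60 nM to 600 nM.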

Compound 4, half-maximal inhibitory concentration: 70 nM
For compound 4 the middle estimate is 2.6-fold (0.41 log units) above the measured one, within the range that was stated.
By their numbers in this assay, from the lowest: compounds 3 and 4 (each within the scatter of the next); then compound 1. At a limit, above all of these: compound 2.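

In this assay phenyl in place of 3,5-dimethylphenyl on a saturated chain carbon bound to an amide-type nitrogen in a ring leaves the read-out flat (no change at the digits printed from compound 3 to compound 4 (within the scatter)). Among these compounds, this is the first measured pair that isolates this place, and it shows that the potency of compound 3 does not depend on its methyl groups. No measured evidence shown here bears on why this step is flat. From the compounds shown here alone, whether an amine, a carboxylic acid or a longer chain at this place would keep the number stays open.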